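Notes on the step from compound 2 to compound 3

The source may report more compounds than this note shows. Statements on the series, on what has been measured and on what is new or still open speak of the compounds shown alone.

compound 1 `CN(C)c1ccc(-c2nn(Cc3ccc(C#N)cc3)c(=O)c3ccccc23)c(F)n1`: 79200 nM
compound 2 `N#Cc1ccc(Cn2nc(-c3ccc(N)nc3F)c3ccccc3c2=O)cc1`: > 100000 nM (a limit)

Going by the values given here, both entries come from an ADME assay on HepG2 2.2.15 cells (Homo sapiens) for cytotoxicity, read by MTT assay, with a stated time of 8 days (on this read-out higher numbers stand for lower toxicity in this test and lower numbers for higher toxicity in this test), and are the only data so far. In this assay compound 2 gives > 100000 nM as a limit of the assay and not a number, so its place is known only as the limit of > 100000 nM in this assay, at which 1 of the 2 values shown sits.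

Compound 3 `Cc1ccc(-c2nn(Cc3ccc(C#N)cc3)c(=O)c3ccccc23)c(F)n1` carries methyl in place of amino on an aromatic carbon, next to the ring nitrogen and para to a large group, turning 6-amino-2-fluoropyridin-3-yl into 2-fluoro-6-methylpyridin-3-yl. The counted difference is methyl in place of amino on an aromatic carbon.

Among the compounds with values here, the only measured step at this carbon is an at least 1.2-fold higher number from compound 1 to compound 2 (0.10 log units; that floor lies within the scatter), and it swaps amino for dimethylamino, not for methyl, so it bears on the change only indirectly. With a non-amino group on that carbon, compound 1 gives 79200 nM as a true number. No step beyond the scatter is therefore expected, and any small move would more likely be towards a lower number. The estimated step is an at least 1.2-fold lower number from compound 2 to compound 3 (0.09 log units; that floor lies within the scatter). For compound 3 the expected value is 80000 nM, with an estimated range of 35000 nM to 100000 nM.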

Compound 3, half-maximal cytotoxic concentration: > 100000 nM
Compound 3 ended at the assay's limit; the forecaster's own chance of this, stated with the estimate: 40%; middle value at least 1.2-fold (0.09 log units) away from the limit.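

In this assay compound 3 gives > 100000 nM, which is a limit of the assay and not a number. With methyl in place of dimethylamino on this aromatic carbon, the change gives an at least 1.2-fold higher number from compound 1 to compound 3 (0.10 log units; that floor lies within the scatter), so only a floor is known and it does not separate the two compounds. The step between compound 2 and compound 3 cannot be read, but the earlier compounds showed only amino at the limit, whereas methyl, counted with no hydrogen-bond donor or acceptor, now stands there too: the limit of > 100000 nM in this assay, at which 2 of the 3 values shown sit.

On these data alone, how far compound 2 and compound 3 lie past the limit, and whether they differ from each other at all, remains open. As far as these compounds go, it is also open whether a carboxylic acid or a longer chain such as butyl on this carbon would stay at the limit or give a true number. Compound 1 gives a true number, 79200 nM.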